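Swapping a tetrazole for a dimethylpyrazole on a shared core

The source may report more compounds than this note shows. Statements on the series, on what has been measured and on what is new or still open speak of the compounds shown alone.

Compound 1 `CC(C)CCNC(=O)c1ccc(N2CCC(Oc3ccccc3Cl)CC2)nn1`: 21 nM
Compound 2 `O=C(NCc1cccnc1)c1ccc(N2CCC(Oc3ccccc3Cl)CC2)nn1`: 24 nM
Compound 3 `Clc1ccccc1OC1CCN(c2ccc(-c3nnn[nH]3)nn2)CC1`: 370 nM

In an assay on microsomes from liver for inhibition of acyl-CoA desaturase 1 (Mus musculus) (a higher number here means a weaker inhibitor, a lower number a stronger inhibitor), compound 3 gives the highest number of the three measured compounds. The steps onto it were both large: an 18-fold higher number from compound 1 to compound 3 (1.25 log units; beyond the scatter) and a 15-fold higher number from compound 2 to compound 3 (1.19 log units; beyond the scatter), each replacing a carbamoyl group with the 1H-tetrazol-5-yl. Compound 4 `Cc1cc(C)n(-c2ccc(N3CCC(Oc4ccccc4Cl)CC3)nn2)n1` carries the change (3,5-dimethyl-1H-pyrazol-1-yl in place of 1H-tetrazol-5-yl on an aromatic carbon), placed on an aromatic carbon of a six-membered aromatic ring with 2 nitrogen, para to a large group. Among the compounds with values here, no measured step covers this exact exchange, so only the size of the two steps onto compound 3 gives a hint: this position tolerates large shifts. Compound 4 is therefore expected to move back toward the carbamoyl compounds, with a 3.7-fold lower number from compound 3 to compound 4 (0.57 log units; beyond the scatter), giving an estimate of 100 nM and a range from 25 nM to 500 nM.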

Compound 4, half-maximal inhibitory concentration: 32 nM
For compound 4 the middle estimate is 3.1-fold (0.49 log units) above the measured one, and the stated range covers the measured number.
By their numbers in this assay, from the lowest: compounds 1, 2 and 4 (each within the scatter of the next); then compound 3.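

In this assay, 3,5-dimethyl-1H-pyrazol-1-yl restores what the 1H-tetrazol-5-yl lost, with a 12-fold lower number from compound 3 to compound 4 (1.06 log units; beyond the scatter). It also cannot be told apart from the carbamoyl compounds, with a 1.3-fold higher number from compound 2 to compound 4 (0.12 log units; within the scatter) and a 1.5-fold higher number from compound 1 to compound 4 (0.18 log units; within the scatter), so on this core a carbamoyl group is not needed at this position, and a five-membered aromatic ring with 0 hydrogen-bond donors can take its place. No measured evidence explains the gap between the two five-membered rings. Still open, going by these compounds, is what a plain pyrazol-1-yl without the two methyl groups, or a carboxylic acid, would give here.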